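Swapping bromo for butyl on a weak antiproliferative scaffold

The source may report more compounds than this note shows. Statements on the series, on what has been measured and on what is new or still open speak of the compounds shown alone.

Compound 1 `O=C1c2ccccc2C(=O)N1C/C=C\Cn1cc(C#Cc2ccc(Br)cc2)c(=O)[nH]c1=O` gives 87000 nM in a functional assay on HeLa cells (Homo sapiens) for antiproliferative activity, read by MTT assay, with a stated time of 3 days (on this read-out higher numbers stand for weaker inhibition and lower numbers for stronger inhibition), the highest of the three numbers at hand and, as both gaps lie beyond the scatter, the weakest inhibitor. Compound 2 `CCCCCCC#Cc1cn(C/C=C/CN2C(=O)c3ccccc3C2=O)c(=O)[nH]c1=O` gives 34000 nM in this assay, and compound 3 `O=C1c2ccccc2C(=O)N1C/C=C/Cn1cc(C#CCCc2ccccc2)c(=O)[nH]c1=O` gives 29000 nM. Compound 4 `CCCCc1ccc(C#Cc2cn(C/C=C\CN3C(=O)c4ccccc4C3=O)c(=O)[nH]c2=O)cc1` differs from compound 1 by butyl in place of bromo on an aromatic carbon, sitting para to a large group; one bond further out this reads 4-bromophenyl to 4-butylphenyl. Within the data shown here, no measured pair carries this exact swap. Among the measured compounds shown here, the only step touching a butyl group, a 1.2-fold lower number from compound 2 to compound 3 (0.07 log units; within the scatter), is small, so no shift beyond the scatter is expected. Compound 4 is therefore estimated at 55000 nM, between 20000 nM and 150000 nM, an expected step of a 1.6-fold lower number from compound 1 to compound 4 (0.20 log units; within the scatter).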

Compound 4, half-maximal inhibitory concentration: 85000 nM
Compound 4: middle estimate off by 1.5-fold (0.19 log units), on the low side, and the stated range covers the measured number.
By their numbers in this assay, from the lowest: compounds 3 and 2 (each within the scatter of the next); then compounds 4 and 1 (each within the scatter of the next).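

In this assay, butyl in place of bromo on an aromatic carbon, para to a large group, leaves the number within the scatter (a 1.0-fold lower number from compound 1 to compound 4 (0.01 log units; within the scatter)). Among these compounds, this is the first direct reading at this position, and it shows that going from 1 heavy atom to 4 carbon atoms here brings no measurable change in inhibition. Nothing at hand offers an explanation for this flat result.

On these data alone, whether an amine or a carboxylic acid at this position would move the number remains open. So does the effect of a longer chain there.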